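A Furan Replaces Thiophene in Compound 3

This account rests on a few compounds, and the source may have more. Where it says the series, first, only, none or still open, it means among the compounds named here.

- Compound 1 `CC(C)n1ncc2c(C(=O)Nc3ccc(F)cc3)cc(-c3cccs3)nc21`: > 200000 nM
- Compound 2 `CC(C)n1ncc2c(C(=O)Nc3ccc(F)cc3)cc(-c3ccsc3)nc21`: > 200000 nM

Both entries come from an ADME assay on LLC-MK2 cells (Macaca mulatta) for cytotoxicity, read by spectrophotometry and crystal violet staining, with a stated time of 4 days (a higher number here means that more compound is tolerated, a lower number that less compound is tolerated), and neither is an exact number. Compound 2 stands only at a limit of > 200000 nM. Compound 1 gives the same kind of result, a limit of > 200000 nM. Together they form the whole picture so far: the limit of > 200000 nM in this assay, at which 2 of the 2 values shown sit.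

Compound 3 `CC(C)n1ncc2c(C(=O)Nc3ccc(F)cc3)cc(-c3ccco3)nc21` has furan-2-yl in place of thiophen-3-yl on an aromatic carbon, next to the ring nitrogen (furan-2-yl in place of thiophen-3-yl on an aromatic carbon). Among the compounds with values here, the one measured step that bears on this change also exchanges one five-membered aromatic ring for another: a step that the two limits leave unreadable from compound 1 to compound 2. Its size cannot be read, so it offers no sign of a real shift, and no step beyond the scatter is expected in this assay. The expected change is a number no higher from compound 2 to compound 3 (the limit leaves the size open). Compound 3 is estimated at 200000 nM, with an expected range of 90000 nM to 200000 nM.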

Compound 3, half-maximal cytotoxic concentration: > 200000 nM
Compound 3 gave a limit, no number; the forecaster's own chance of this, stated with the estimate: 70%; the middle value lies on the limit itself.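

Within the data shown here, compound 3 also gives a limit rather than a number, so no step among compound 1, compound 2 and compound 3 can be read, and all three share one result: the limit of > 200000 nM in this assay, at which 3 of the 3 values shown sit. The compounds shown leave open how much of each compound the cells tolerate, and whether exchanging the five-membered aromatic ring changes that.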